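This account rests on a few compounds, and the source may have more. Where it says the series, first, only, none or still open, it means among the compounds named here.

The measured compounds and their values:

Compound 1, `COc1ncc(-c2ccc3ncnc(Nc4ccc(OCCO)cc4)c3c2)cc1NS(C)(=O)=O`, gives 5200 nM in a functional assay on A549 cells (Homo sapiens) for antiproliferative activity, read by sulforhodamine B assay, with a stated time of 72 h; on this read-out lower numbers stand for stronger inhibition and higher numbers for weaker inhibition.
Compound 2, `COc1ncc(-c2ccc3ncnc(Nc4ccc(OCCO)c(Cl)c4)c3c2)cc1NS(=O)(=O)c1ccc(F)cc1F`, gives 5980 nM in this assay.
Compound 3, `COC(=O)CCn1cc(Nc2ncnc3ccc(-c4cnc(OC)c(NS(C)(=O)=O)c4)cc23)cn1`, gives 2990 nM in this assay.

Compound 3 has the lowest number of the three, but its gap to compound 1 and to compound 2 stays within the scatter, so none of the three can be called more or less potent than another. Among the measured compounds shown here, the only single-place step among them is a 1.7-fold lower number from compound 1 to compound 3 (0.24 log units; within the scatter), and that step too lies within the scatter.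

Compound 4, `COc1ncc(-c2ccc3ncnc(Nc4cnn(CCC(=O)O)c4)c3c2)cc1NS(C)(=O)=O`, is not yet measured. It differs from compound 3 in one place: hydrogen in place of methyl on an oxygen next to a carbonyl group. Put another way, the methoxycarbonyl of compound 3 becomes a carboxy group in compound 4.

No measured step touches this part of the structure, so nothing shown gives a direction for it. The step in this assay from compound 3 to compound 4 is therefore expected to stay within the scatter, as a 1.2-fold higher number from compound 3 to compound 4 (0.07 log units; within the scatter). Compound 4 is estimated at 3500 nM, with a range from 1400 nM to 9000 nM.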

Compound 4, half-maximal inhibitory concentration: 3840 nM
Estimate against measurement, compound 4: 1.1-fold (0.04 log units) below; low and high end bracket the measured number.
By their numbers in this assay, from the lowest: compounds 3, 4, 1 and 2 (each within the scatter of the next).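

Among the compounds shown here, replacing the methyl of the methoxycarbonyl with hydrogen gives the first measured step at this end of the molecule: in this assay, there is a 1.3-fold higher number from compound 3 to compound 4 (0.11 log units; within the scatter), so the methyl ester and the carboxy group cannot be told apart here. The other new step, a 1.4-fold lower number from compound 1 to compound 4 (0.13 log units; within the scatter), shows that 1-(2-carboxyethyl)-1H-pyrazol-4-yl likewise cannot be separated from 4-(2-hydroxyethoxy)phenyl on the nitrogen. No measurement is available that would explain either result.

The compounds shown leave open whether an amide or an amine in place of the carboxy group would shift the number beyond the scatter. They also leave open whether a longer chain carrying the carboxy group would do so.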